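The source may hold more compounds than are shown below. What is called first, only, known or untested is meant among the compounds shown, and "the series" means these compounds.

Measured compounds:
- compound 1, `O=c1ccoc2ccc(OCCc3ccccc3)cc12`, 3120 nM
- compound 2, `O=c1ccoc2ccc(OCc3cccc(Br)c3)cc12`, 386 nM
- compound 3, `O=c1ccoc2ccc(OCc3ccc(Br)cc3)cc12`, 95 nM

These three share one core and differ only in the group hung from its ether oxygen. They were tested in an assay on microsomes for inhibition of Amine oxidase [flavin-containing] A (Homo sapiens), read by fluorescence and spectrophotometry, with a stated time of 20 min; a higher number here means a weaker inhibitor, a lower number a stronger inhibitor. Compound 2, with a bromo on the aromatic carbon meta to the large group, gives 386 nM in this assay. Of the three numbers this is the second highest: its nearest neighbour, compound 3, gives 95 nM, a lower number beyond the usual scatter, while compound 1 gives 3120 nM, a higher number, also beyond the scatter. Compound 2 thus sits between the two, closer to compound 3.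

Compound 4 is `N#Cc1cccc(COc2ccc3occc(=O)c3c2)c1`, not yet measured in this assay. It differs from compound 2 in one place: cyano in place of bromo on an aromatic carbon, a cyano in place of bromo on an aromatic carbon. Among the measured compounds shown here, no measured pair shows this exchange, so there is no step to lean on; what is known is only where compound 2 stands and how far the other two lie from it.

Because compound 2 gives 386 nM, compound 4 is expected to land near that value, with a step from compound 2 to compound 4 of about a 1.7-fold higher number from compound 2 to compound 4 (0.23 log units; within the scatter), probably toward a somewhat higher number, though it may also stay within the scatter. The estimate for compound 4 in this assay is 650 nM, in a range from 200 nM to 2200 nM.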

Compound 4, half-maximal inhibitory concentration: 255 nM
For compound 4 the middle estimate is 2.5-fold (0.41 log units) above the measured one; the range from low to high includes it.
By their numbers in this assay, from the lowest: compound 3; then compounds 4 and 2 (each within the scatter of the next); then compound 1.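

In this assay, cyano in place of bromo on the aromatic carbon gives a 1.5-fold lower number from compound 2 to compound 4 (0.18 log units; within the scatter), so the two groups cannot be told apart at this place. Among the compounds shown here, until now, bromo was the only group seen here; this exchange shows that a second, quite different group can sit on the same carbon with no change beyond the scatter, even though cyano has two heavy atoms, a triple bond and one hydrogen-bond acceptor, while bromo has one heavy atom and no acceptor. Nothing measured here gives a reason for this match.

Only these two groups have been seen at this place, so a methyl, a methoxy, an amine or a carboxylic acid on the same aromatic carbon could give a number close to these or far from them. Going by these compounds, it also stays open whether the same exchange on the aromatic carbon that carries the bromo in compound 3 would likewise stay within the scatter.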